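Hydrogen in place of amino on a fused two-ring core

A few compounds are considered here, and "the series" means these few. Any claim that something is new, unique, unknown or untested is made for them only; others in the source may bear on it.

The account concerns compound 1 `Nc1nc(Cl)c2ncn(Cc3ccccc3CCl)c2n1`, its close relative compound 2 `ClCc1ccccc1Cn1cnc2nc(Cl)nc(Cl)c21`, and the unmeasured compound 3 `ClCc1ccccc1Cn1cnc2c(Cl)ncnc21`. In a functional assay on Hs-578T cells (Homo sapiens) for cytotoxicity, read by sulforhodamine B assay, with a stated time of 48 h (a lower number here means that less compound is tolerated, a higher number that more compound is tolerated), compound 1 gives > 100000 nM, which is a limit of the assay rather than a measured number. Compound 2 returns > 100000 nM in this assay, again only a limit. Among the measured compounds shown here, compound 1 thus stands where (the limit of > 100000 nM in this assay, at which 2 of the 2 values shown sit), and the two values show only that neither compound reached half-maximal kill within the range tested; no ordering between them can be drawn.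

The change from compound 1 to compound 3 is hydrogen in place of amino on an aromatic carbon. For the measured compounds named here, no measured pair in this set charts such a change, so nothing here points to a step beyond the scatter in either direction. With compound 1 already at the assay limit, compound 3 is expected to remain near that same limit in this assay, estimated at 150000 nM with a range from 40000 nM to 500000 nM. The expected step that the limit leaves unreadable from compound 1 to compound 3 is accordingly close to none.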

Compound 3, concentration lethal to 50% of the cells: 56200 nM
The estimate for compound 3 lay 2.7-fold (0.43 log units) above the measured number; the range from low to high includes it.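

With compound 3, this series gives its first true number rather than a limit in this assay, so the carbon between two ring nitrogen atoms can now be tied to a readable value. Hydrogen in place of amino at this position gives an at least 1.7-fold lower number from compound 1 to compound 3 (0.25 log units; that floor lies within the scatter), a one-sided step whose true size may be larger than this floor. Compound 1 supplies only the upper end of that comparison, and the floor alone does not establish a change beyond the scatter, so the result shows that the amino group's loss is compatible with less compound being tolerated without proving it; most of the set remains unresolved: the limit of > 100000 nM in this assay, at which 2 of the 3 values shown sit.

Among the compounds shown here, compound 1 and compound 2 both rest on limits, so no step between them can be read, and the size of the amino group's contribution stays unknown. From the compounds shown here alone, whether a methyl, a hydroxyl or a methylamino group on that same aromatic carbon would give a number like that of compound 3, or would stay at the limit, remains open.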